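This account rests on a few compounds, and the source may have more. Where it says the series, first, only, none or still open, it means among the compounds named here.

Compound 1 `O=C(Nc1cccc(-n2cc(-c3ccncc3)c(-c3ccc(Cl)c(O)c3)n2)c1)Nc1ccc(Cl)c(Cl)c1`: in a functional assay on NCI-H23 cells (Homo sapiens) for inhibition, read by sulforhodamine B assay, with a stated time of 48 h (on this read-out higher numbers stand for lower toxicity in this test and lower numbers for higher toxicity in this test), compound 1 gives > 32500 nM, which is a limit of the assay rather than a number.
Compound 2 `COc1cc(-c2nn(-c3cccc(NC(=O)c4ccc(Cl)c(C(F)(F)F)c4)c3)cc2-c2ccncc2)ccc1Cl`: in this assay compound 2 gives > 32500 nM, again a limit and not a number.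
Compound 3 `O=C(Nc1cccc(-n2cc(-c3ccncc3)c(-c3ccc(Cl)c(O)c3)n2)c1)Nc1cc(C(F)(F)F)cc(C(F)(F)F)c1`: in this assay compound 3 gives 18200 nM.

Compound 1 stands at a limit of this assay, so its true value is only known to lie beyond that point. The same holds for compound 2, as the limit of > 32500 nM in this assay, at which 2 of the 3 values shown sit, shows, and compound 3 is the only one of the three with a measured number, which is itself a weak one. No pair among these three differs in a single place, so no measured step can be drawn from them.

Compound 4 `O=C(Nc1cccc(-n2cc(-c3ccncc3)c(-c3ccc(Cl)c(O)c3)n2)c1)Nc1ccc(Cl)c(C(F)(F)F)c1` is the partner of compound 1 on this step. The change is trifluoromethyl in place of chloro on an aromatic carbon. A trifluoromethyl also appears on the outer ring of compound 3, but compound 3 carries two of them and lacks the chloro, so it offers only a loose hint. Compound 4 is expected to stay weak, with a step of an at least 1.0-fold lower number from compound 1 to compound 4 (0.03 log units; that floor lies within the scatter) that most likely sits within the scatter or ends at a limit. Compound 4 is therefore estimated at 30000 nM, between 12000 nM and 65000 nM.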

Compound 4, concentration lethal to 50% of the cells: 26100 nM
Compound 4: the middle estimate sits 1.1-fold (0.06 log units) above what was measured; the measured number falls inside the stated range.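

In this assay compound 1 offers only a limit, > 32500 nM, so the 3,4-dichlorophenyl group gave this position no number to start from. Trifluoromethyl in place of chloro, ortho to a chloro group, gives an at least 1.2-fold lower number from compound 1 to compound 4 (0.09 log units; that floor lies within the scatter); that floor proves no real change, but compound 4 now gives this position its first fixed number. How far the true step runs stays unknown because its starting point is not a number: the limit of > 32500 nM in this assay, at which 2 of the 4 values shown sit.

The compounds shown leave open whether a quite different group at this position, such as an amine, a nitrile or a carboxylic acid, would move the number beyond the scatter. They also leave open whether the same swap of chloro for trifluoromethyl, read from a starting compound with a true number, would stay within the scatter or prove larger.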